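This account rests on a few compounds, and the source may have more. Where it says the series, first, only, none or still open, it means among the compounds named here.

Measured so far in a functional assay on the whole organism (strain Kunming) with Mus musculus as the target, with a stated time of 0.5 h, at a dose of 100 mg/kg by the intraperitoneal route; a higher number here means a weaker effect of the compound at the dose given, a lower number a stronger effect:

compound 1 `COc1ccccc1/C=C/C(=O)OC/C=C/c1cc(OC)c(OC)cc1OC` — compound 1 gives 100%
compound 2 `COc1cc(OC)c(OC)cc1/C=C/COC(=O)/C=C/c1ccc(Br)cc1` — compound 2 gives 100%
compound 3 `COc1cc(OC)c(OC)cc1/C=C/COC(=O)/C=C/c1ccc(OC)c(OC)c1OC` — compound 3 gives 100%

On these numbers compound 2 stands level with compound 1 and compound 3 at the digits given; the values of compound 2 and compound 3 are the same figure, and the step of no change at the digits printed from compound 1 to compound 2 (within the scatter) lies within the scatter. Compound 4 `COc1cc(OC)c(OC)cc1/C=C/COC(=O)/C=C/c1ccccc1Cl` has not yet been measured in this assay. It differs from compound 2 in one place: 2-chlorophenyl in place of 4-bromophenyl on a double-bonded chain carbon bound to a double-bonded chain carbon. Going by the values given here, the one measured step that bears on this is the step from compound 1 to compound 2, which also exchanges the aryl group at the same place and shows no change at the digits printed from compound 1 to compound 2 (within the scatter); the value of compound 3, carrying yet another aryl group there, is again the same figure. Nothing in these three compounds points to a shift beyond the scatter for compound 4, so the expected step is no change at the digits printed from compound 2 to compound 4 (within the scatter). Compound 4 is therefore estimated at 100%, within a range from 90% to 100%.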

Compound 4, a percentage reported as activity, at one dose (the size of the read-out at that dose, not a potency): 100%
Compound 4: the middle estimate sits on the measured number at the digits printed; measured number inside the range.
By their numbers in this assay, from the lowest: compounds 1, 2, 3 and 4 (each within the scatter of the next).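

In this assay, the exchange of 4-bromophenyl for 2-chlorophenyl alters both the halogen and its printed position on the phenyl ring, yet it gives no change at the digits printed from compound 2 to compound 4 (within the scatter). Chloro in place of methoxy on an aromatic carbon likewise gives no change at the digits printed from compound 1 to compound 4 (within the scatter), so this place on the double-bonded chain now tolerates a chloro-bearing ring as well as the bromo- and methoxy-bearing rings without any separation among the compounds. No measurement bears on why these values coincide.

With all the compounds at one figure, the set gives no order among the aryl groups and does not show which part of the structure governs the read-out. On these data alone, whether a phenyl ring carrying an amine or a carboxylic acid at this place would depart from that figure remains open.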